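The source may report more compounds than this note shows. Statements on the series, on what has been measured and on what is new or still open speak of the compounds shown alone.

Of the compounds shown here, two have been measured in a physicochemical assay for lipophilicity, at pH 7.4; a lower number here means a more polar compound, a higher number a more lipophilic compound. Compound 1 `Cc1cc(C)c(CN2CCc3c(Cl)cc(-c4c(C)noc4C)c(Cl)c3C2=O)c(=O)[nH]1` gives 3.1. Compound 2 `COc1cc(C)[nH]c(=O)c1CN1CCc2c(Cl)cc([C@@H](O)C3COC3)c(Cl)c2C1=O` gives 1.3, the lower of the two numbers, and the gap up to compound 1 lies beyond the usual scatter, so compound 2 clearly stands as the more polar of the pair.

Compound 3 `COc1cc(C)[nH]c(=O)c1CN1CCc2c(Cl)cc(-c3c(C)noc3C)c(Cl)c2C1=O` has not yet been measured. It arises from compound 2 by one change: a group of 7 heavy atoms (5 carbon, 1 nitrogen, 1 oxygen; one five-membered aromatic ring with 2 hetero atoms) in place of a group of 6 heavy atoms (4 carbon, 2 oxygen; one four-membered non-aromatic ring with 1 hetero atom), on an aromatic carbon. The group that leaves brings one hydrogen-bond donor with it; the 3,5-dimethyl-1,2-oxazol-4-yl group that enters has none, and it is the same group that compound 1 carries at that position.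

Going by the values given here, no measured pair shows this exact step, so its size has to be guessed. A large rise in this assay is expected, because compound 1, which carries the entering group, gives 3.1. The expected step from compound 2 to compound 3 is a number 1.60 log units higher from compound 2 to compound 3 (beyond the scatter). For compound 3 the estimate is 2.9, with a range from 2.4 to 3.4.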

Compound 3, distribution coefficient: 2.7
The estimate for compound 3 lay 0.20 log units above the measured number; the range from low to high includes it.
By their numbers in this assay, from the lowest: compound 2; then compound 3; then compound 1.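

At the aromatic carbon ortho to a chloro group, putting 3,5-dimethyl-1,2-oxazol-4-yl in place of the group with the four-membered ring gives, in this assay, a number 1.40 log units higher from compound 2 to compound 3 (beyond the scatter), a large step that shows how strongly the reading depends on what sits at this position. The second new pair tests a different place on the molecule: methoxy in place of methyl on an aromatic carbon gives a number 0.40 log units lower from compound 1 to compound 3 (beyond the scatter), a modest step that still lies outside the normal variation between repeat measurements, so this small exchange also registers in this assay. No measurement shown here explains either step.

The four-membered ring and the hydrogen-bond donor leave together between compound 2 and compound 3, so the compounds shown cannot separate what each contributes to the step. Going by these compounds alone, it also remains open how this assay would respond at the same aromatic carbon to an amine, a carboxylic acid or a longer chain, since only two kinds of group appear there.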